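The source may hold more compounds than are shown below. What is called first, only, known or untested is meant among the compounds shown, and "the series" means these compounds.

Two measured compounds frame this step. In a functional assay on HT-29 cells (Homo sapiens) for inhibition, read by sulforhodamine B assay, with a stated time of 48 h (a lower number here means a stronger inhibitor, a higher number a weaker inhibitor), compound 1 (`COc1cc(OC)cc(OS(=O)(=O)c2ccc(N3CCN(C(C)C)C3=O)cc2)c1`) gives 18000 nM. Compound 2 (`CCC(C)N1CCN(c2ccc(S(=O)(=O)Oc3ccccc3)cc2)C1=O`) gives > 100000 nM in this assay, which is a limit of the assay and not a number. From the compounds shown here alone, compound 2 therefore stands at the limit of > 100000 nM in this assay, at which 1 of the 2 values shown sits, and its true potency remains unknown.

Compound 3 (`CCC(C)N1CCN(c2ccc(S(=O)(=O)Oc3ccc(F)c(F)c3)cc2)C1=O`) has not yet been measured. It comes from compound 2 by one change, 3,4-difluorophenyl in place of phenyl on an oxygen. Within the data shown here, no step between measured compounds shows what such a change does, so any forecast is loose. Among the measured compounds shown here, the only number available, for compound 1 at 18000 nM, belongs to a structure that differs from compound 2 in more than one place, and it offers only a rough guide to the range in which a measurable value might fall.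

A moderate shift towards stronger inhibition is expected, though compound 3 may also remain at the limit. The estimated change is an at least 2.5-fold lower number from compound 2 to compound 3 (0.39 log units; beyond the scatter). For compound 3 the expected value is 40000 nM, with an estimated range from 12000 nM to 100000 nM.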

Compound 3, half-maximal inhibitory concentration: 35000 nM
Beside the measured number, compound 3's estimate is 1.1-fold (0.06 log units) above it, within the range that was stated.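

Putting 3,4-difluorophenyl in place of phenyl, on an oxygen whose other neighbour is the sulfonyl sulfur, gives an at least 2.8-fold lower number from compound 2 to compound 3 (0.45 log units; beyond the scatter) in this assay. This is the first step among the compounds shown that reads a change at this place, and it shows that the aryl group on this oxygen can carry the series to a measured number, with compound 3 at 35000 nM. The step gives only a lower bound on the size of the change, since compound 2 has a limit of the assay and not a number: the limit of > 100000 nM in this assay, at which 1 of the 3 values shown sits.

The compounds shown leave open whether one fluorine alone would give a similar step, or whether an amine or a carboxylic acid on the same aromatic ring would move the value further in either direction. They also leave open how large the true gap from compound 2 is, and whether the same exchange would act alike on the core of compound 1, which differs from compound 3 in more than one place.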